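Swapping Ethyl for Methoxy: Expected Tolerance in Cells

The source may hold more compounds than are shown below. What is called first, only, known or untested is meant among the compounds shown, and "the series" means these compounds.

Of the compounds shown here, two sharing a core have so far been tested in a functional assay on RD cells (Homo sapiens) for inhibition, read by luminescence and ATP content, with a stated time of 72 h; a lower number here means that less compound is tolerated, a higher number that more compound is tolerated. Compound 1 `CCOC(=O)c1cnc2ccc(-c3ccc(N)cc3)cc2c1` gives only a limit of the assay, > 7400 nM, rather than a number. Compound 2 `CCc1ccc(-c2ccc3ncc(-c4noc(C)n4)cc3c2)cc1` likewise reaches only a limit in this assay, recorded as > 7400 nM. Where compound 2 stands is therefore simple: it sits at the limit of > 7400 nM in this assay, at which 2 of the 2 values shown sit, so both values so far are limits and no difference between them can be read. Among the measured compounds shown here, no step between measured compounds that differ in a single place is available.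

Compound 3 `COc1ccc(-c2ccc3ncc(-c4noc(C)n4)cc3c2)cc1` differs from compound 2 in one place: methoxy in place of ethyl on an aromatic carbon. Since both measured compounds sit at the limit, the only expectation that rests on the data is a step in this assay of none beyond the scatter, estimated as a step that the limit leaves unreadable from compound 2 to compound 3. Compound 3 is accordingly expected to give 10000 nM, within a range from 5000 nM to 30000 nM, most likely reported again as a limit.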

Compound 3, half-maximal cytotoxic concentration: > 66700 nM
Compound 3: only a limit was reported; the forecaster's own chance of this, stated with the estimate: 85%; at least 6.6-fold (0.82 log units) between middle value and limit.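

Among the compounds shown here, compound 2 and compound 3 each give only a limit in this assay, not a number, so no step between them can be read. The compounds shown leave open whether methoxy in place of ethyl on an aromatic carbon changes the half-maximal cytotoxic concentration at all, and by how much.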